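A Methoxy Group Added to Two Sulfonamide Cores

The compounds below may be only part of what the source reports. "The series", "measured", "known", "first", "only" and "open" are said of these compounds alone.

Compound 1, `C#CCOc1ccccc1/C=N/Cc1ccc(S(N)(=O)=O)cc1`: in a functional assay on HT-29 cells (Homo sapiens) for cytotoxicity, read by MTT assay, with a stated time of 24 h (a lower number here means a stronger inhibitor, a higher number a weaker inhibitor), compound 1 gives 31000 nM.
Compound 2, `C#CCOc1c(/C=N/Cc2ccc(S(N)(=O)=O)cc2)cccc1OC`: compound 2 gives 81300 nM.
Compound 3, `NS(=O)(=O)c1ccc(C/N=C/c2ccc(OCc3cn(CCCOc4ccc5ccc(=O)oc5c4)nn3)cc2)cc1`: compound 3 gives 125000 nM.

Compound 1 and compound 2 share one core, and compound 3 carries another; how the two cores differ is not broken down here. The number for compound 3 lies within the scatter of that for compound 2 and beyond the scatter from that for compound 1.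

The change from compound 1 to compound 2 is methoxy in place of hydrogen on an aromatic carbon. It produced a 2.6-fold higher number from compound 1 to compound 2 (0.42 log units; beyond the scatter).

Compound 4, `COc1cc(/C=N/Cc2ccc(S(N)(=O)=O)cc2)ccc1OCc1cn(CCCOc2ccc3ccc(=O)oc3c2)nn1`, is not yet measured. Its change from compound 3 is methoxy in place of hydrogen on an aromatic carbon. This is the same kind of change as the earlier one, not the same: in compound 2 the methoxy is ortho to a propargyloxy group, whereas in compound 4 it is ortho to a large group; in both it is meta to a large group.

For the measured compounds named here, only one earlier step of this kind exists, so the expectation for compound 4 rests on it alone and is held loosely. Going by the values given here, a step of similar direction and size is estimated, a 2.0-fold higher number from compound 3 to compound 4 (0.30 log units; within the scatter), because a 2.6-fold higher number from compound 1 to compound 2 (0.42 log units; beyond the scatter) is the single precedent. Compound 4 is therefore expected to give about 250000 nM in this assay. The range for compound 4 is estimated to run from 100000 nM to 600000 nM.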

Compound 4, half-maximal inhibitory concentration: 31600 nM
Estimate against measurement, compound 4: 7.9-fold (0.90 log units) above; measured number outside the range, below it.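

In this assay the methoxy in place of hydrogen on an aromatic carbon gave a 4.0-fold lower number from compound 3 to compound 4 (0.60 log units; beyond the scatter) and so made the second compound of this pair the stronger inhibitor. Set beside the earlier step on the other core, the same change did not carry over, and even its direction was reversed: the same change on two cores in this assay, a 2.6-fold higher number (0.42 log units; beyond the scatter) from compound 1 to compound 2 and a 4.0-fold lower number (0.60 log units; beyond the scatter) from compound 3 to compound 4, 10-fold (1.02 log units) apart, beyond the scatter of two such steps. This shows that in these two pairs the result of adding a methoxy depended on the compound receiving it, so a step measured on one core was a poor guide to the step on the other, but it does not show what causes the difference: the cores differ, the methoxy has a propargyloxy group as its neighbour in one pair and a large group in the other, and two pairs are too few to separate these or to set a rule for the series.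

Going by these compounds, it remains open whether an ethoxy group, a hydroxyl group or a fluorine atom in place of that hydrogen would shift the number in opposite directions on the two cores, as the methoxy does. On these data alone, it is also open whether the methoxy step on the core of compound 3 would hold with a longer chain in the linker.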